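Chloro for ethyl on the aryl urea of a cyclic amidine

The source may hold more compounds than are shown below. What is called first, only, known or untested is meant among the compounds shown, and "the series" means these compounds.

The series rests on one shared core carrying an aryl urea. Compound 1 `CCc1cccc(CC)c1NC(=O)/N=C1\CCCN1C` has been examined in a functional assay on the whole organism with Rattus norvegicus as the target, with a stated time of 5 days; on this read-out higher numbers stand for an effect only at larger amounts of compound and lower numbers for an effect already at smaller amounts. In this assay compound 1 reaches only a limit, > 25 mg/kg, which is the limit at which one of the two values shown sits (the limit of > 25 mg/kg in this assay, at which 1 of the 2 values shown sits). Compound 2 `CCc1cccc(C)c1NC(=O)/N=C1\CCCN1C` has in this assay only the entry "not determined" (no result reported), so no number places it relative to compound 1. Compound 3 `Cc1cccc(Cl)c1NC(=O)/N=C1\CCCN1C` is the next compound to be tested. It differs from compound 2 by chloro in place of ethyl on an aromatic carbon. Going by the values given here, no step between measured compounds exists here, so the size of the change from compound 2 to compound 3 in this assay cannot be read from the data; the expectation is a step that stays within the usual scatter, in no set direction. Compound 3 is therefore expected to show a minimum effective dose near 25 mg/kg, in a range from 6 mg/kg to 100 mg/kg.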

Compound 3, minimum effective dose: > 25 mg/kg
Compound 3: no number, only a limit; the forecaster's own chance of this, stated with the estimate: 60%; the middle value sits exactly at the limit.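

Going by these compounds alone, no step from compound 2 to compound 3 can be read in this assay. Compound 3 gives only a limit, > 25 mg/kg. The compounds shown leave open at what dose any of them takes effect, and they share one boundary: the limit of > 25 mg/kg in this assay, at which 2 of the 3 values shown sit.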